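The compounds below may be only part of what the source reports. "The series", "measured", "known", "first", "only" and "open" are said of these compounds alone.

Three compounds share a four-membered ring core bearing a methoxy group and a nitrogen that carries a styryl-type arm. Compound 1 `CCOC(=O)/C(=C/c1ccccc1)CN1C(=O)[C@@H](OC)[C@H]1c1cccc([N+](=O)[O-])c1` has an ethyl ester on that arm and a nitrophenyl on the ring; in a functional assay on MDA-MB-231 cells (Homo sapiens) for antiproliferative activity, read by MTT assay, with a stated time of 48 h (on this read-out lower numbers stand for stronger inhibition and higher numbers for weaker inhibition), compound 1 gives 14400 nM. Compound 2 `CO[C@@H]1C(=O)N(C/C(C#N)=C/c2ccccc2)[C@@H]1c1ccc(Cl)cc1Cl` carries a nitrile on the arm and a 2,4-dichlorophenyl on the ring, and compound 2 gives 17000 nM. Compound 3 `COC(=O)/C(=C/c1ccccc1)CN1C(=O)[C@@H](OC)[C@H]1c1ccccc1` has a methyl ester on the arm and a plain phenyl on the ring, and compound 3 gives 11100 nM, the lowest of the three numbers, though the gaps to compound 1 and compound 2 both lie within the usual scatter of such measurements.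

Compound 4 `COC(=O)/C(=C/c1ccccc1)CN1C(=O)[C@@H](OC)[C@H]1c1ccc(Cl)cc1Cl` keeps the methyl ester of compound 3 and changes only the ring substituent: 2,4-dichlorophenyl in place of phenyl on a saturated ring carbon. Compound 2 already carries this same 2,4-dichlorophenyl and gives 17000 nM, close to the others. The step of a 1.2-fold higher number from compound 3 to compound 4 (0.07 log units; within the scatter) is therefore expected to be small, with no direction beyond the scatter. Compound 4 is estimated at 13000 nM, within a range from 6000 nM to 30000 nM.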

Compound 4, half-maximal inhibitory concentration: 19000 nM
The estimate for compound 4 lay 1.5-fold (0.16 log units) below the measured number; measured number inside the range.
By their numbers in this assay, from the lowest: compounds 3, 1, 2 and 4 (each within the scatter of the next).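

Within the data shown here, this is the first pair here that differs in one place only: with the methyl ester arm held fixed, 2,4-dichlorophenyl in place of phenyl on a saturated ring carbon gives a 1.7-fold higher number from compound 3 to compound 4 (0.23 log units; within the scatter) in this assay as the read-out. At this position, then, adding the two chlorine atoms to the phenyl shifts the number by no more than repeated measurements of this kind can do on their own. Nothing measured here offers an explanation for this result.

The compounds shown leave open whether another kind of group on this phenyl, such as an amine or a hydroxyl, would move the number beyond the scatter. Also open, going by these compounds, is what a carboxylic acid in place of the methyl ester on the arm would do.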